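Benzamide series: anilino to methylpiperidinyl swap at the chloro-bearing core

The compounds below may be only part of what the source reports. "The series", "measured", "known", "first", "only" and "open" are said of these compounds alone.

Measured so far:
compound 1, `Nc1ccccc1NC(=O)c1ccc(Cn2cnc3c(Nc4ccccc4)nc(Cl)nc32)cc1`, 74.8%
compound 2, `Nc1ccccc1NC(=O)c1ccc(Cn2cnc3c(Nc4cccc(OC(F)(F)F)c4)nc(Cl)nc32)cc1`, 31.2%

In a functional assay on HepG2 cells (Homo sapiens) for antiproliferative activity, read by CCK-8 assay, with a stated time of 72 h, tested at 8 uM (a higher number here means a stronger effect of the compound at the concentration tested, a lower number a weaker effect), compound 2 gives 31.2% and stands lowest of the two numbers recorded; its nearest neighbour is compound 1, which in this assay gives 74.8%. Within the data shown here, the single measured step, a number 43.6 percentage points lower from compound 1 to compound 2 (beyond the scatter), is the only comparison in hand.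

Compound 3, `CC1CCN(c2nc(Cl)nc3c2ncn3Cc2ccc(C(=O)Nc3ccccc3N)cc2)CC1`, is not yet measured. It differs from compound 2 by 4-methylpiperidin-1-yl in place of (3-(trifluoromethoxy)phenyl)amino on an aromatic carbon. The measured step runs in the opposite sense only in part: it concerns adding trifluoromethoxy to the phenyl of the (3-(trifluoromethoxy)phenyl)amino group, whereas the change to compound 3 removes that whole group and brings in 4-methylpiperidin-1-yl, for which no comparison exists. As far as these compounds go, because compound 1 without the trifluoromethoxy gives 74.8%, a move upward from compound 2 seems plausible, but the swap of an aromatic amino group for a saturated ring is untested, so the expectation is wide. The step expected from compound 2 to compound 3 in this assay is a number 23.8 percentage points higher from compound 2 to compound 3 (beyond the scatter). Compound 3 is estimated at 55%, in the range 25% to 80%.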

Compound 3, a percentage reported as inhibition, at one concentration (the size of the read-out at that concentration, not a potency): 65.3%
For compound 3 the middle estimate is 10.3 percentage points below the measured one, within the range that was stated.
By their numbers in this assay, from the lowest: compound 2; then compounds 3 and 1 (each within the scatter of the next).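

In this assay, the aromatic carbon of the shared core that carries anilino in compound 1 also tolerates a saturated ring: the step is a number 9.5 percentage points lower from compound 1 to compound 3 (within the scatter), so 4-methylpiperidin-1-yl and anilino cannot be told apart in this read-out, even though the entering group has 0 hydrogen-bond donors and no aromatic ring. The other new comparison is a number 34.1 percentage points higher from compound 2 to compound 3 (beyond the scatter), which shows that the low number of compound 2 does not hold for every group at this carbon and, among the three compounds shown, is seen only with (3-(trifluoromethoxy)phenyl)amino. No measurement in hand accounts for either step.

The compounds shown leave open whether the methyl group of the piperidine contributes anything, which unsubstituted piperidine would address, and whether a ring with a second hetero atom, such as morpholine or 4-methylpiperazine, fits the same picture. They also leave open whether trifluoromethoxy on the anilino ring is matched by a smaller substituent such as fluoro or methoxy at that ring position.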